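Tail flick series: from compound 2 to compound 4

The compounds below may be only part of what the source reports. "The series", "measured", "known", "first", "only" and "open" are said of these compounds alone.

Measured so far:
compound 1, `C[C@H](NC(=O)CN(c1nc(Cl)nc2[nH]cnc12)C1CC1)C(=O)OCc1ccccc1`, 64.3% 
compound 2, `CC(C)[C@H](NC(=O)CN(c1nc(Cl)nc2[nH]cnc12)C1CC1)C(=O)OCc1ccccc1`, 55.5% 
compound 3, `O=C(CN(c1ncnc2c1ncn2C1CCCCO1)C1CC1)N[C@@H](CCC(=O)OCc1ccccc1)C(=O)OCc1ccccc1`, 34.7% 

In a functional assay on the whole organism (Tail, strain ICR) with Mus musculus as the target, in the tail flick test, with a stated time of 60 min, at a dose of 25 umol/kg by the oral route (a lower number here means a weaker effect, a higher number a stronger effect of the compound at the dose given), compound 2 stands second of the three numbers, with compound 1 nearest and compound 3 furthest. Among the compounds with values here, the one measured step, a number 8.8 percentage points lower from compound 1 to compound 2 (within the scatter), lies within the scatter and concerns the same position as the change now considered. Compound 4, `O=C(CN(c1nc(Cl)nc2[nH]cnc12)C1CC1)N[C@@H](CC(=O)OCc1ccccc1)C(=O)OCc1ccccc1`, is not yet measured; it differs from compound 2 by (benzyloxycarbonyl)methyl in place of isopropyl on a saturated chain carbon bound to an amide-type nitrogen and a carbonyl carbon. Within the data shown here, no measured step covers this change directly. Compound 3 carries a related dibenzyl ester on a different core and gives a lower number than compound 2. On that basis a downward step is expected, a number 13.5 percentage points lower from compound 2 to compound 4 (beyond the scatter), and compound 4 is estimated at 42%, within 22% to 62%.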

Compound 4, a percentage reported as activity, at one dose (the size of the read-out at that dose, not a potency): 22.4%
The estimate for compound 4 lay 19.6 percentage points above the measured number; low and high end bracket the measured number.
By their numbers in this assay, from the lowest: compound 4; then compound 3; then compounds 2 and 1 (each within the scatter of the next).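

Changes at this position are not all small in this assay: (benzyloxycarbonyl)methyl in place of isopropyl gives a number 33.1 percentage points lower from compound 2 to compound 4 (beyond the scatter) and is the first single change here to lie beyond the scatter. Benzyloxycarbonyl in place of hydrogen on the saturated chain carbon gives a step of similar direction (a number 41.9 percentage points lower from compound 1 to compound 4 (beyond the scatter)), so this side chain counts against the number from both smaller alkyl neighbours. No measured data bear on the cause of this drop.

As far as these compounds go, whether the benzyl ester or the added chain carbon carries the loss remains open. A carboxylic acid or a primary amine at the end of the same side chain would help separate the two.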